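The compounds below may be only part of what the source reports. "The series", "measured", "known", "first", "only" and "open" are said of these compounds alone.

Of the compounds shown here, two of a shared core have been measured in a functional assay on CCRF-CEM cells (Homo sapiens) for inhibition, read by sulforhodamine B assay, with a stated time of 48 h; on this read-out higher numbers stand for weaker inhibition of growth and lower numbers for stronger inhibition of growth. Compound 1, `COc1ccc(-c2ccc(-c3ccc(C(=N)N)cc3)s2)cc1`, carries a methoxy group on its outer ring and gives 231 nM in this assay. Compound 2, `N=C(N)c1ccc(-c2ccc(-c3cc(Cl)cc(Cl)c3)s2)cc1`, carries two chloro groups on that ring instead and gives 1540 nM. Compound 1 thus stands at the lowest of the two numbers, and its gap to compound 2 is well beyond the usual scatter of repeated measurements, so compound 1 is the stronger inhibitor of growth of the two.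

Compound 3, `N=C(N)c1ccc(-c2ccc(-c3ccc(F)cc3)s2)cc1`, has not yet been measured. It differs from compound 1 in one place: fluoro in place of methoxy on an aromatic carbon. Within the data shown here, since no measured pair shows exactly this swap, the expectation rests on compound 1 and on the picture from compound 2, where a different halogen pattern on the same ring gave a weaker result. The step expected from compound 1 to compound 3 in this assay is a 1.7-fold higher number from compound 1 to compound 3 (0.24 log units; within the scatter), a modest rise that may stay within the scatter. For compound 3 the estimate is 400 nM, with a range from 150 nM to 1100 nM.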

Compound 3, concentration for 50% growth inhibition: 1820 nM
Compound 3: middle estimate off by 4.6-fold (0.66 log units), on the low side; the whole stated range lies below it.
By their numbers in this assay, from the lowest: compound 1; then compounds 2 and 3 (each within the scatter of the next).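

In this assay, putting fluoro in place of methoxy on this aromatic carbon, para to a large group, brings a 7.9-fold higher number from compound 1 to compound 3 (0.90 log units; beyond the scatter) and so a clear loss of growth inhibition. Among these compounds, this is the first direct reading of a single change at this position, and it shows that the position is not indifferent to what sits on it: exchanging one small group for another, with only one heavy atom fewer, moves the number beyond the scatter. Nothing in the available data explains why this swap weakens growth inhibition.

The compounds shown leave open how other groups would fare at this same position, such as a hydroxyl group, a methyl group, an ethoxy group or an amine. A hydroxyl group would keep the oxygen of methoxy without its carbon and a methyl group would keep the carbon without the oxygen, so that pair could show which part of methoxy the number follows, while an ethoxy group would test a longer chain on the same oxygen.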